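A few compounds are considered here, and "the series" means these few. Any claim that something is new, unique, unknown or untested is made for them only; others in the source may bear on it.

Going by the values given here, in a functional assay on HCT-116 cells (Homo sapiens) for antiproliferative activity, read by MTT assay, with a stated time of 48 h (a higher number here means a weaker inhibitor, a lower number a stronger inhibitor), compound 1 (`O=C(/C=C/c1ccccn1)c1nc2ccccc2[nH]1`) gives 60 nM as the only actual number so far. Compound 2 (`O=C(/C=C/c1ccccn1)c1nc2ccccc2o1`) gives > 100000 nM and this is a limit of the assay, not a number. Compound 3 (`O=C(/C=C/c1cccc(Cl)c1)c1nc2ccccc2o1`) gives > 100000 nM and this too is a limit. Among the compounds with values here, compound 1 therefore stands alone as the one compound with a measured potency, and there is no series of numbers against which to rank it.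

The next compound, compound 4 (`O=C(/C=C/c1ccccc1)c1nc2ccccc2[nH]1`), keeps the core of compound 1 and alters a single group. The change is phenyl in place of pyridin-2-yl, on a double-bonded chain carbon bound to a double-bonded chain carbon (phenyl in place of pyridin-2-yl on a double-bonded chain carbon bound to a double-bonded chain carbon). Within the data shown here, no measured pair shows what this swap does on its own, so any forecast is loose. One six-membered aromatic ring replaces another and the rest of the molecule stays the same, so a complete loss of activity seems less likely than a partial one. In this assay the expected result is a 6.7-fold higher number from compound 1 to compound 4 (0.82 log units; beyond the scatter) and that would be a moderate weakening, beyond the usual scatter but well short of the limit. For compound 4 the estimated value is 400 nM with a wide expected range of 40 nM to 8000 nM for now.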

Compound 4, half-maximal inhibitory concentration: 200 nM
For compound 4 the middle estimate is 2.0-fold (0.30 log units) above the measured one; the measured number falls inside the stated range.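

In this assay, going by these compounds alone, putting phenyl in place of pyridin-2-yl gives a 3.3-fold higher number from compound 1 to compound 4 (0.52 log units; beyond the scatter), the first step in this set that can be read as a size, and a modest one. At this place, on a double-bonded chain carbon bound to a double-bonded chain carbon, the ring nitrogen of pyridin-2-yl is therefore not essential: compound 4, with a ring of carbon only, keeps a measured potency, although the change does cost some of it. Compound 2 and compound 3 could not show this, since each gives only a limit of the assay and not a number, so no size of effect can be read from either: the limit of > 100000 nM in this assay, at which 2 of the 4 values shown sit.

As far as these compounds go, what remains open is how far this position tolerates other groups on the core of compound 1, for example a phenyl ring carrying a methoxy group or an amine, or a saturated ring such as cyclohexyl. A single pair also cannot tell why the step has this size, or whether the same swap would have a similar effect on a different core.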